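The source may report more compounds than this note shows. Statements on the series, on what has been measured and on what is new or still open speak of the compounds shown alone.

Measured so far in an assay on isolated protein for inhibition of Arachidonate 12-lipoxygenase (Sus scrofa); on this read-out higher numbers stand for weaker inhibition and lower numbers for stronger inhibition: compound 1 `CCCCCCCCC#CCOCc1cccc(CCC(=O)O)c1` gives 10000 nM; compound 2 `CCCCCCCCC#CCOCc1ccc(CCC(=O)O)cc1` gives 100 nM; compound 3 `O=C(O)CCc1cccc(COCC#CCCCCCc2ccccc2)c1` gives 5000 nM.

On these numbers compound 2 stands lowest, and its gaps to compound 3 and compound 1 both lie beyond the scatter. Compound 4 `O=C(O)CCc1ccc(COCC#CCCCCc2ccccc2)cc1` differs from compound 2 in one place: phenyl in place of butyl on a saturated chain carbon, four bonds along the chain from a triple-bonded carbon. Among the measured compounds shown here, the only measured step that bears on this is the closely related one from the core of compound 1, a 2.0-fold lower number from compound 1 to compound 3 (0.30 log units; within the scatter), which lay within the scatter. The same kind of exchange on the core of compound 2 is therefore expected to give no step beyond the scatter in this assay, a 1.4-fold lower number from compound 2 to compound 4 (0.15 log units; within the scatter). Compound 4 is estimated at 70 nM, with a range from 25 nM to 250 nM.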

Compound 4, half-maximal inhibitory concentration: 5000 nM
Compound 4: the middle estimate sits 71-fold (1.85 log units) below what was measured; measured number above the stated range.
By their numbers in this assay, from the lowest: compound 2; then compounds 3, 4 and 1 (each within the scatter of the next).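

In this assay, phenyl in place of butyl is far from a neutral exchange on the core of compound 2, giving a 50-fold higher number from compound 2 to compound 4 (1.70 log units; beyond the scatter). The closely related exchange on the core of compound 1 gave only a 2.0-fold lower number from compound 1 to compound 3 (0.30 log units; within the scatter), so a change of this kind in the chain cannot be carried from one core to the other. Nothing available here accounts for this difference.

As far as these compounds go, it remains open whether a cyclohexyl group at this place on the core of compound 2 would behave like butyl or like phenyl.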